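Working notes: from compound 2 to compound 3

This account rests on a few compounds, and the source may have more. Where it says the series, first, only, none or still open, it means among the compounds named here.

Values in a functional assay on A549 cells (Homo sapiens) for cytotoxicity, read by MTT assay, with a stated time of 72 h (a lower number here means a stronger inhibitor, a higher number a weaker inhibitor), so far
- Compound 1 `COc1cccc(/C=C2\CCC/C(=C\c3ccc(O)c(O)c3)C2=O)c1OC` gives > 20000 nM as a limit of the assay
- Compound 2 `COc1ccc(/C=C2\CCC/C(=C\c3cccc(Br)c3)C2=O)cc1OC` gives 12800 nM as a number

Among the measured compounds shown here, compound 2 (12800 nM) holds the only numerical value so far. For the measured compounds named here, the one other result is the limit recorded for compound 1, so no measured step is available to size the next change.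

The next compound is compound 3 `COc1ccc(/C=C2\CCC/C(=C\c3ccc(Cl)cc3Cl)C2=O)cc1OC`, not yet measured. It carries 2,4-dichlorophenyl in place of 3-bromophenyl on a double-bonded chain carbon bound to a double-bonded ring carbon, and the counted difference is 2,4-dichlorophenyl in place of 3-bromophenyl on a double-bonded chain carbon bound to a double-bonded ring carbon in full. The remainder of compound 2 is kept.

With only compound 2 (12800 nM) as a numerical reference, no change beyond the usual scatter is expected in this assay and no direction is favoured. The expected step is a 1.3-fold lower number from compound 2 to compound 3 (0.11 log units; within the scatter) and the estimate carries a wide range. Compound 3 is expected at 10000 nM in this assay with an estimated range from 4000 nM to 20000 nM on this reading.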

Compound 3, half-maximal inhibitory concentration: > 20000 nM
Compound 3 gave a limit, no number (the forecaster's own chance of this, stated with the estimate: 20%); middle value at least 2.0-fold (0.30 log units) away from the limit.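

In this assay compound 3 gives > 20000 nM, which is a limit of the assay and not a number. Among the compounds shown here, exchanging 3-bromophenyl for 2,4-dichlorophenyl on a double-bonded chain carbon bound to a double-bonded ring carbon, with the rest of the molecule kept, gives the first readable step, an at least 1.5-fold higher number from compound 2 to compound 3 (0.19 log units; that floor lies within the scatter), so this change points towards a higher number but does not establish a difference beyond the usual scatter. The step can be read only as a floor, and its true size stays unknown, because the assay stops at its limit: the limit of > 20000 nM in this assay, at which 2 of the 3 values shown sit.

Compounds 2 and 3 leave open how far compound 3 lies past the limit, and whether the two chlorines, their placement on the phenyl or the loss of the bromine accounts for the direction, as the change was counted as one whole group. They also leave open whether a phenyl carrying an amine or a carboxylic acid at this place would give a number lower than that of compound 2, or would also end at the limit.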